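Methoxypyridinyl replacement on the anilino arm of compound 1

A few compounds are considered here, and "the series" means these few. Any claim that something is new, unique, unknown or untested is made for them only; others in the source may bear on it.

Measured so far in a functional assay on SNU-638 cells (Homo sapiens) for cytotoxicity, read by sulforhodamine B assay, with a stated time of 72 h; a lower number here means a stronger inhibitor, a higher number a weaker inhibitor:
- compound 1 `CCS(=O)(=O)Nc1cc(-c2ccc3ncnc(Nc4ccc(OC)c(OC)c4)c3c2)cnc1OC`: 1680 nM
- compound 2 `CCCCS(=O)(=O)Nc1cc(-c2ccc3ncnc(Nc4ccc(F)c(Cl)c4)c3c2)cnc1OC`: 5350 nM
- compound 3 `CCCCS(=O)(=O)Nc1cc(-c2ccc3ncnc(Nc4cccc(C(=O)OCC)c4)c3c2)cnc1OC`: 25200 nM

Compound 1 gives the lowest number of the three in this assay; compound 2 stands next to it and compound 3 furthest away. For the measured compounds named here, compound 1 and compound 2 differ in two places at once, so their two values show only that the pair is separated, not which change carries it. Going by the values given here, the one single-point step available is a 4.7-fold higher number from compound 2 to compound 3 (0.67 log units; beyond the scatter), which shows that exchanging the aryl group on the anilino nitrogen moves the number by a modest but real amount within the shared core.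

Compound 4 `CCS(=O)(=O)Nc1cc(-c2ccc3ncnc(Nc4ccc(OC)nc4)c3c2)cnc1OC` is not yet measured. It differs from compound 1 by 6-methoxypyridin-3-yl in place of 3,4-dimethoxyphenyl on a nitrogen on an aromatic ring. Among the compounds with values here, no measured pair covers this exact exchange; the only comparison that bears on it is the aryl exchange from compound 2 to compound 3, which weakened the inhibitor. On that basis a step of the same sign is expected, with the change to compound 4 estimated as a 1.8-fold higher number from compound 1 to compound 4 (0.25 log units; within the scatter). Compound 4 is expected to give about 3000 nM in this assay, within 1000 nM to 9000 nM.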

Compound 4, half-maximal inhibitory concentration: 4280 nM
Beside the measured number, compound 4's estimate is 1.4-fold (0.15 log units) below it; the range from low to high includes it.
By their numbers in this assay, from the lowest: compound 1; then compounds 4 and 2 (each within the scatter of the next); then compound 3.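

In this assay the exchange on the anilino nitrogen gives a 2.5-fold higher number from compound 1 to compound 4 (0.41 log units; beyond the scatter) and so lies beyond the scatter, which shows that the aryl group at this position also moves the number when the sulfonyl carries an ethyl chain, not only in the butyl pair compound 2 and compound 3. Here 6-methoxypyridin-3-yl, with the smaller heavy-atom count, gives a higher number than 3,4-dimethoxyphenyl even though the two groups have equal counts of hydrogen-bond donors and acceptors, so those equal counts do not keep the number in place across this pair. Nothing measured here accounts for the size or direction of this step.

The exchange alters the ring atoms and the methoxy count together, so a phenyl ring with a single methoxy group, or an unsubstituted pyridinyl ring, on the ethyl series would be needed to separate the two parts. The effect of the sulfonyl chain alone also stays open, since no pair shown differs only there, and a propyl chain or a cyclopropyl group with the aryl group held fixed would address it.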